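A few compounds are considered here, and "the series" means these few. Any claim that something is new, unique, unknown or untested is made for them only; others in the source may bear on it.

Measured so far:
Compound 1, `CN(Cc1ccc(S(C)(=O)=O)cc1)C1CCN(CCCc2c[nH]c3ccc(-n4cnnc4)cc23)CC1`: 18 nM
Compound 2, `CC(C)=CCN(C)C1CCN(CCCc2c[nH]c3ccc(-n4cnnc4)cc23)CC1`: 0.5 nM

Going by the values given here, in an assay on CHO cells for displacement of a labelled ligand from 5-hydroxytryptamine receptor 1D (Homo sapiens) (a lower number here means a stronger inhibitor, a higher number a weaker inhibitor), compound 2 gives 0.5 nM, the lowest of the two numbers, and the only measured step is a 36-fold lower number from compound 1 to compound 2 (1.56 log units; beyond the scatter). Compound 3, `c1cc(CNC2CCN(CCCc3c[nH]c4ccc(-n5cnnc5)cc34)CC2)co1`, is not yet measured; its change from compound 2 is ((furan-3-yl)methyl)amino in place of methyl(3-methylbut-2-en-1-yl)amino on a saturated ring carbon. Among the compounds with values here, the one step on record removed an aromatic ring from this amine for an unsaturated chain and gave a large drop, so putting an aromatic ring back, here a smaller one, is expected to raise the number, though less than that step did. Compound 3 is therefore expected to give 5 nM, between 1.5 nM and 20 nM, a step of a 10-fold higher number from compound 2 to compound 3 (1.00 log units; beyond the scatter).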

Compound 3, half-maximal inhibitory concentration: 4.5 nM
Beside the measured number, compound 3's estimate is 1.1-fold (0.05 log units) above it, and the stated range covers the measured number.
By their numbers in this assay, from the lowest: compound 2; then compound 3; then compound 1.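

In this assay the swap to ((furan-3-yl)methyl)amino gives a 9.0-fold higher number from compound 2 to compound 3 (0.95 log units; beyond the scatter), so this saturated ring carbon can carry an aromatic ring while compound 3 still reads 4.5 nM. The swap also removes the methyl from the amine nitrogen and adds a hydrogen-bond donor, so the step cannot be pinned on any one of these changes. No measured evidence here explains the step.

Still open, from the compounds shown here alone, is how compound 3 would read with a methyl restored on that nitrogen, or with a phenyl or furan-2-yl ring replacing the furan-3-yl.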